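Furanoyl amide in place of phenylbutanoyl on the shared core

A few compounds are considered here, and "the series" means these few. Any claim that something is new, unique, unknown or untested is made for them only; others in the source may bear on it.

Compound 3 `O=C(CCCc1ccccc1)Nc1ccc(N2CCN(c3ccc(OC[C@@H]4CO[C@@](Cn5cncn5)(c5ccc(Cl)cc5Cl)O4)cc3)CC2)cc1` gives 3780 nM in a functional assay on A549 cells (Homo sapiens) for inhibition, read by MTT assay, with a stated time of 48 h (on this read-out higher numbers stand for weaker inhibition and lower numbers for stronger inhibition), and stands second highest of three numbers there. Its nearest neighbour is compound 1 `CCCC(=O)Nc1ccc(N2CCN(c3ccc(OC[C@@H]4CO[C@@](Cn5cncn5)(c5ccc(Cl)cc5Cl)O4)cc3)CC2)cc1`, which gives 2990 nM, and the pair lie within the scatter, as a 1.3-fold higher number from compound 1 to compound 3 (0.10 log units; within the scatter) shows. Compound 2 `O=C(CC1CCOCC1)Nc1ccc(N2CCN(c3ccc(OC[C@@H]4CO[C@@](Cn5cncn5)(c5ccc(Cl)cc5Cl)O4)cc3)CC2)cc1` gives 10000 nM and is furthest away; the step of a 2.6-fold lower number from compound 2 to compound 3 (0.42 log units; beyond the scatter) is modest but beyond the scatter, as is a 3.3-fold higher number from compound 1 to compound 2 (0.52 log units; beyond the scatter).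

Compound 4 `O=C(Nc1ccc(N2CCN(c3ccc(OC[C@@H]4CO[C@@](Cn5cncn5)(c5ccc(Cl)cc5Cl)O4)cc3)CC2)cc1)c1ccco1` differs from compound 3 by furan-2-yl in place of 3-phenylpropyl on a carbonyl carbon. Going by the values given here, no measured step places an aromatic ring directly on the carbonyl carbon, so the three steps bear on it only loosely: the amide substituent has moved the number by modest amounts at most, and the compounds bracket a narrow range. Compound 4 is therefore expected to stay within that range, with a step of a 1.3-fold higher number from compound 3 to compound 4 (0.12 log units; within the scatter) that is small and of uncertain direction. Compound 4 is estimated at 5000 nM, between 2000 nM and 15000 nM.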

Compound 4, half-maximal inhibitory concentration: 10500 nM
Beside the measured number, compound 4's estimate is 2.1-fold (0.32 log units) below it; the measured number falls inside the stated range.
By their numbers in this assay, from the lowest: compounds 1 and 3 (each within the scatter of the next); then compounds 2 and 4 (each within the scatter of the next).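

In this assay, furan-2-yl on the carbonyl carbon gives a 2.8-fold higher number from compound 3 to compound 4 (0.44 log units; beyond the scatter) and a 3.5-fold higher number from compound 1 to compound 4 (0.55 log units; beyond the scatter), so this position responds to the change beyond the scatter even though propyl and 3-phenylpropyl, which differ greatly in size, stayed within it. Against (oxan-4-yl)methyl the result is a 1.1-fold higher number from compound 2 to compound 4 (0.02 log units; within the scatter), within the scatter, which shows that two quite different groups can share the weaker level, and that a ring in the substituent does not alone decide the level, since compound 3 also carries one and goes against any such reading. Nothing available accounts for the shift at this position.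

The compounds shown leave open whether the shift follows from the ring oxygen of furan-2-yl or from a ring placed directly on the carbonyl carbon. A phenyl or thiophen-2-yl group on that carbon would bear on this question, as would a furan-2-yl group carried on a short saturated chain.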